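A few compounds are considered here, and "the series" means these few. Any claim that something is new, unique, unknown or untested is made for them only; others in the source may bear on it.

Compound 1, `COc1cncc(N2CC[C@H]3CN[C@H]3C2)c1`, was tested in a functional assay on HEK293 cells for agonist activity at Neuronal acetylcholine receptor; alpha4/beta2 (Homo sapiens), read by FLIPR (on this read-out lower numbers stand for an effect already at smaller amounts and higher numbers for an effect only at larger amounts of compound), where compound 1 gives 130 nM. Compound 2, `COc1cc(N2CC[C@H]3CN[C@H]3C2)cnc1Br`, differs from compound 1 by bromo in place of hydrogen on an aromatic carbon and in this assay compound 2 gives 21 nM, a step of a 6.2-fold lower number from compound 1 to compound 2 (0.79 log units; beyond the scatter). Compound 3, `N#Cc1cncc(N2C[C@@H]3CCNC[C@@H]32)c1`, rests on a different core; the difference between the two cores is not broken down here. In this assay compound 3 gives 2190 nM. Compound 4, `N#Cc1cc(N2C[C@@H]3CCNC[C@@H]32)cnc1Br`, is derived from compound 3 by the same kind of change, (bromo in place of hydrogen on an aromatic carbon); the entering bromo now sits ortho to a cyano group rather than ortho to a methoxy group. Going by the values given here, the step from compound 3 to compound 4 is expected to be a 4.9-fold lower number from compound 3 to compound 4 (0.69 log units; beyond the scatter), resting on the single earlier step of a 6.2-fold lower number from compound 1 to compound 2 (0.79 log units; beyond the scatter) and allowing for the changed surroundings. Compound 4 is therefore estimated at 450 nM, expected between 150 nM and 1300 nM.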

Compound 4, half-maximal effective concentration: 109 nM
Estimate against measurement, compound 4: 4.1-fold (0.62 log units) above, outside the stated range (below it).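

In this assay, bromo in place of hydrogen on an aromatic carbon again gives a lower number on the second core, with a 20-fold lower number from compound 3 to compound 4 (1.30 log units; beyond the scatter) and thus the same direction as on the core of compound 1. The size of the change did not carry over: the same change on two cores in this assay, a 6.2-fold lower number (0.79 log units; beyond the scatter) from compound 1 to compound 2 and a 20-fold lower number (1.30 log units; beyond the scatter) from compound 3 to compound 4, 3.2-fold (0.51 log units) apart, beyond the scatter of two such steps. Going by these compounds alone, with only one pair on each core, this does not show whether the larger step belongs to the core itself or to the cyano group in compound 4, which replaces the methoxy group of compound 2.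

The compounds shown leave open how the two cores would compare with a methoxy group on the core of compound 3 or a cyano group on the core of compound 1. They also leave open whether chloro or a methyl group in place of bromo would give steps that differ in the same way.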